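The source may report more compounds than this note shows. Statements on the series, on what has been measured and on what is new or still open speak of the compounds shown alone.

Measured so far:
- compound 1, `CC(C)(C)c1cc(NC(=O)Nc2ccc(Nc3ncnc4c3OCCN4)cc2)no1`: 58 nM
- compound 2, `CC(C)(C)c1csc(NC(=O)Nc2ccc(Nc3ncnc4c3OCCN4)cc2)n1`: > 10000 nM

In an assay on isolated protein for inhibition of proto-oncogene tyrosine-protein kinase receptor Ret variant V804L (Homo sapiens), read by 33P incorporation, with stated times of 15 min and 40 min (on this read-out lower numbers stand for stronger inhibition and higher numbers for weaker inhibition), compound 1 gives 58 nM. Compound 2 returns only a limit, > 10000 nM, not a number. Among the measured compounds shown here, the one measured step, an at least 170-fold higher number from compound 1 to compound 2 (2.23 log units; beyond the scatter), rests on (the limit of > 10000 nM in this assay, at which 1 of the 2 values shown sits). For the measured compounds named here, compound 1 therefore stands as the only numeric value shown; the other result is a limit.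

Compound 3, `Cc1cc(NC(=O)Nc2cc(C(C)(C)C)on2)ccc1Nc1ncnc2c1OCCN2`, differs from compound 1 by methyl in place of hydrogen on an aromatic carbon of a six-membered carbon-only ring, ortho to a large group and meta to a large group. Going by the values given here, the measured step swapped the heteroaryl on the urea nitrogen and does not touch this ring, so no measured step bears on this change. A step of a 1.2-fold higher number from compound 1 to compound 3 (0.08 log units; within the scatter) is expected, within the scatter. Compound 3 is estimated at 70 nM, between 25 nM and 250 nM.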

Compound 3, half-maximal inhibitory concentration: 85 nM
The estimate for compound 3 lay 1.2-fold (0.08 log units) below the measured number; the range from low to high includes it.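

In this assay, the step to compound 3 is the first one shown on the six-membered aromatic ring of carbon only, and methyl in place of hydrogen there gives a 1.5-fold higher number from compound 1 to compound 3 (0.17 log units; within the scatter). Among the compounds shown here, the earlier step changed only the heteroaryl on the urea nitrogen, so this is the first sign that the ring carbon ortho to a large group and meta to a large group can carry a methyl with no change that stands out from the scatter. No result shown gives a reason for this outcome.

Going by these compounds, a single methyl says little about what else this carbon can carry, so a chlorine, a methoxy group or a longer chain such as ethyl remains open. On these data alone, the other carbons of this ring remain open as well.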